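The source may hold more compounds than are shown below. What is called first, only, known or untested is meant among the compounds shown, and "the series" means these compounds.

Among the measured compounds shown here, in a functional assay on NCI-H520 cells (Homo sapiens) for cytotoxicity (a lower number here means a stronger inhibitor of growth, a higher number a weaker inhibitor of growth), compound 1 `CSc1ccc(C2=C(c3ccc(C)c(C)c3)C(=O)N3CCCC3C2)cc1` gives 300 nM, the lowest of the two numbers measured so far. The other measured compound, compound 2 `COc1ccc(C2=C(c3ccc(SC)cc3)CC3CCCN3C2=O)cc1OC`, gives 2000 nM. Compound 3 `CSc1ccc(C2=C(c3ccc(F)cc3)C(=O)N3CCCC3C2)cc1` carries 4-fluorophenyl in place of the 3,4-dimethylphenyl of compound 1 on a double-bonded ring carbon: 4-fluorophenyl in place of 3,4-dimethylphenyl on a double-bonded ring carbon. For the measured compounds named here, no measured pair shows this change, so the expectation is loose: a modest rise in the number, meaning a weaker inhibitor of growth. The expected step is a 2.0-fold higher number from compound 1 to compound 3 (0.30 log units; within the scatter). For compound 3, the estimated value is 600 nM, with an expected range of 150 nM to 2500 nM.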

Compound 3, concentration for 50% growth inhibition: 250 nM
Compound 3: middle estimate off by 2.4-fold (0.38 log units), on the high side; the measured number falls inside the stated range.
By their numbers in this assay, from the lowest: compounds 3 and 1 (each within the scatter of the next); then compound 2.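

In this assay, among the compounds shown here, the first direct reading at this double-bonded ring carbon puts 4-fluorophenyl in place of 3,4-dimethylphenyl with a 1.2-fold lower number from compound 1 to compound 3 (0.08 log units; within the scatter) and so does not separate the two groups. The earlier compounds shown here offered no pair differing in one place, so this exchange is the only one that can be read at this position. Nothing measured here accounts for this result. From the compounds shown here alone, whether a carboxylic acid, an amine or a pyridine ring at this carbon would give a similar number remains open. So does the effect of replacing the 4-(methylsulfanyl)phenyl group.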